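A dichlorothiophen isomer swap on compound 2

The compounds below may be only part of what the source reports. "The series", "measured", "known", "first", "only" and "open" are said of these compounds alone.

In an ADME assay on L6 cells (Rattus norvegicus) for cytotoxicity, read by resazurin assay, with a stated time of 72 h (a lower number here means a stronger inhibitor, a higher number a weaker inhibitor), compound 1 (`O=[N+]([O-])c1ncn(CCCNS(=O)(=O)c2cc(Cl)sc2Cl)n1`) gives 119000 nM and compound 2 (`O=[N+]([O-])c1nccn1CCCNS(=O)(=O)c1cc(Cl)sc1Cl`) gives 108000 nM as its reading. Compound 2 therefore stands level with compound 1, the two numbers lying within the scatter of each other. The next structure is compound 3 (`O=[N+]([O-])c1nccn1CCCNS(=O)(=O)c1cc(Cl)c(Cl)s1`), which has the same atoms as compound 2 joined differently: 4,5-dichlorothiophen-2-yl in place of 2,5-dichlorothiophen-3-yl on a sulfonyl sulfur and so 4,5-dichlorothiophen-2-yl in place of 2,5-dichlorothiophen-3-yl on a sulfonyl sulfur. Going by the values given here, no measured pair shows a change of this kind, so the data give no direct guide to its size. With compound 2 at 108000 nM as the starting point, no step beyond the scatter is expected in this assay and no direction is favoured. The estimated 1.1-fold lower number from compound 2 to compound 3 (0.03 log units; within the scatter) is correspondingly small. For compound 3 the expected value is 100000 nM with an estimated range of 50000 nM to 200000 nM in this measurement.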

Compound 3, half-maximal inhibitory concentration: 75000 nM
Compound 3: the middle estimate sits 1.3-fold (0.12 log units) above what was measured, and the stated range covers the measured number.
By their numbers in this assay, from the lowest: compounds 3, 2 and 1 (each within the scatter of the next).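

In this assay, going by these compounds alone, 4,5-dichlorothiophen-2-yl in place of 2,5-dichlorothiophen-3-yl on a sulfonyl sulfur gives a 1.4-fold lower number from compound 2 to compound 3 (0.16 log units; within the scatter) as the only one-place step so far. This step stays within the scatter, so the two dichlorothiophen isomers are not separated at this position, with the rest of compound 2 held constant. Nothing measured here bears on why the readings of the two isomers lie so close.

Left open is whether a different group on the sulfonyl sulfur, such as a phenyl ring or a dibromothiophen, would give a step beyond the scatter. Also open, as far as these compounds go, are whether the same isomer swap reads alike on the core of compound 1, and whether a longer chain leading to the sulfonamide nitrogen shifts the number.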